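Fluorine on the phenyl ring across two oxazole cores

The source may hold more compounds than are shown below. What is called first, only, known or untested is meant among the compounds shown, and "the series" means these compounds.

Of the compounds shown here, three have been measured in a functional assay on CHO cells for agonist activity at Free fatty acid receptor 1 (Homo sapiens), read by FLIPR and calcium flux, in the presence of a further agent that is not named here; a lower number here means that less compound is needed, a higher number that more compound is needed for the effect. Compound 3 `O=C(O)CCc1ccc(OCc2coc(-c3ccccc3)n2)cc1` gives 700 nM. Compound 1 `O=C(O)CCc1ccc(OCc2coc(-c3cccc(F)c3)n2)cc1` gives 560 nM. Compound 2 `O=C(O)CCc1ccc(OCc2nc(-c3ccccc3)no2)cc1` gives 1130 nM. Compound 2 and compound 3 carry different cores; the difference between the two cores is not broken down here.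

Compound 1 and compound 3 differ in one place:

fluoro in place of hydrogen on an aromatic carbon

This change gave a 1.3-fold lower number from compound 3 to compound 1 (0.10 log units; within the scatter).

Compound 4 `O=C(O)CCc1ccc(OCc2nc(-c3ccc(F)cc3)no2)cc1` has not yet been measured in this assay. It differs from compound 2 in this way:

fluoro in place of hydrogen on an aromatic carbon

The change from compound 2 to compound 4 is the same kind of change as that from compound 3 to compound 1, but not the same: in compound 1 the fluoro stands meta to a large group, in compound 4 it stands para to a large group, and the two cores differ as well.

Among the measured compounds shown here, only one earlier step of this kind exists, and it lies within the scatter. On that basis the step from compound 2 to compound 4 is expected to be small, about a 1.3-fold lower number from compound 2 to compound 4 (0.10 log units; within the scatter), because the change from compound 3 to compound 1 gave a 1.3-fold lower number from compound 3 to compound 1 (0.10 log units; within the scatter). For compound 4 the expected value in this assay is 900 nM, with a range of 450 nM to 1800 nM, resting on compound 2 at 1130 nM.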

Compound 4, half-maximal effective concentration: 680 nM
The estimate for compound 4 lay 1.3-fold (0.12 log units) above the measured number; the range from low to high includes it.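

Working notes on the fluoro change: in this assay phenyl to 4-fluorophenyl gives a step of the same direction as the earlier one on the other core (see a 1.7-fold lower number from compound 2 to compound 4 (0.22 log units; within the scatter)), and the two steps agree within the scatter: the same change on two cores in this assay, a 1.3-fold lower number (0.10 log units; within the scatter) from compound 3 to compound 1 and a 1.7-fold lower number (0.22 log units; within the scatter) from compound 2 to compound 4, 1.3-fold (0.12 log units) apart, within the scatter of two such steps

This shows that, across these two pairs, the change can be carried from one core to the other without the result departing from what the first pair gave. It does not show that fluoro lowers the number on either core, since each step on its own lies within the scatter, and two pairs are too few to establish a rule for the series. Nor can the core be separated from the position of the fluoro, as the two pairs differ in both, with the fluoro para to a large group only in compound 4.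

Still open, as far as these compounds go, is whether phenyl to 4-fluorophenyl on the core of compound 3, which would put the same change at the same place on both cores, gives a step like these two. Also open, from the compounds shown here alone, is whether a larger group on the same ring, such as trifluoromethyl, nitrile or methoxy, gives a step beyond the scatter on either core.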